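Adding a Nitro Group to Compound 1

The compounds below may be only part of what the source reports. "The series", "measured", "known", "first", "only" and "open" are said of these compounds alone.

In an ADME assay on H9 cells (Homo sapiens) for cytotoxicity, read by XTT assay, with a stated time of 6 days (a higher number here means that more compound is tolerated, a lower number that less compound is tolerated), compound 1 `Cc1cc(Br)cc(C)c1Oc1ccc([N+](=O)[O-])c(Nc2ccc(C#N)cc2)c1` gives > 57000 nM, which is a limit and not a number. Compound 3 `Cc1cc(C)c(Oc2ccc([N+](=O)[O-])c(Nc3ccc(C#N)cc3)c2)c(C)c1` gives > 67000 nM, also a limit. Compound 2 `Cc1cc(Br)cc(C)c1Oc1ccc(N)c(Nc2ccc(C#N)cc2)c1` gives 44600 nM.

Compound 4 `Cc1cc(Br)cc(C)c1Oc1cc(Nc2ccc(C#N)cc2)c([N+](=O)[O-])cc1[N+](=O)[O-]` carries nitro in place of hydrogen on an aromatic carbon. Within the data shown here, two measured steps bear on this change, though neither adds a nitro group. One is an at least 1.2-fold lower number from compound 1 to compound 2 (0.10 log units; that floor lies within the scatter), with amino in place of nitro. The other is a step that the two limits leave unreadable from compound 1 to compound 3, with methyl in place of bromo. Neither shows a change beyond the scatter, so they offer only a weak guide. A modest estimated move toward a lower number is expected, an at least 1.9-fold lower number from compound 1 to compound 4 (0.27 log units; that floor lies within the scatter). In this assay, compound 4 is expected to give 30000 nM, with an estimated range of 8000 nM to 80000 nM.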

Compound 4, half-maximal cytotoxic concentration: > 51700 nM
Compound 4 gave a limit, no number (the forecaster's own chance of this, stated with the estimate: 40%); middle value at least 1.7-fold (0.23 log units) from the limit.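

Compound 1 and compound 4 both give only limits in this assay, and the step between them cannot be read. The compounds shown leave open whether nitro in place of hydrogen on an aromatic carbon changes the number at all.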